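Swapping a sulfanyl side chain for 4-methylphenoxy

The source may hold more compounds than are shown below. What is called first, only, known or untested is meant among the compounds shown, and "the series" means these compounds.

Half-lives measured in an ADME assay on the whole organism (Rattus norvegicus, strain Lewis) for metabolic stability, at a dose of 2 mg/kg by the oral route; a higher number here means that the compound lasts longer, a lower number that the compound disappears faster
- Compound 1 `N[C@]1(CO)CC[C@H](c2ccc3c(c2)CC[C@@H](COc2ccc(F)cc2)C3)C1` gives 46 h
- Compound 2 `COc1ccccc1SC[C@@H]1CCc2cc([C@H]3CC[C@](N)(CO)C3)ccc2C1` gives 24 h

For the measured compounds named here, compound 2 stands within the scatter of compound 1, the only other compound with a number in this assay so the two cannot be ranked. Going by the values given here, the single measured step is a 1.9-fold lower number from compound 1 to compound 2 (0.28 log units; within the scatter) and it put (2-methoxyphenyl)sulfanyl in place of 4-fluorophenoxy on a saturated chain carbon bound to a saturated ring carbon.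

Compound 3 `Cc1ccc(OC[C@@H]2CCc3cc([C@H]4CC[C@](N)(CO)C4)ccc3C2)cc1` differs from compound 2 at that same place, with 4-methylphenoxy in place of (2-methoxyphenyl)sulfanyl on a saturated chain carbon bound to a saturated ring carbon as the change, which puts 4-methylphenoxy in place of (2-methoxyphenyl)sulfanyl. The entering group is a phenoxy group, as in compound 1, which gives 46 h in this measurement. Among the compounds with values here, the step of a 1.9-fold lower number from compound 1 to compound 2 (0.28 log units; within the scatter) is the only guide at this place, and it stayed within the scatter. One step is thin evidence, and nothing yet shows how a 4-methyl group compares with a 4-fluoro group here. The expected step is a 1.3-fold higher number from compound 2 to compound 3 (0.12 log units; within the scatter) and this estimate stays inside the usual scatter. Compound 3 is expected to show 32 h in this assay with an estimated range from 16 h to 62 h around that figure.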

Compound 3, half-life: 35 h
Estimate against measurement, compound 3: 1.1-fold (0.04 log units) below; low and high end bracket the measured number.
By their numbers in this assay, from the lowest: compounds 2, 3 and 1 (each within the scatter of the next).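

In this assay the new step of a 1.5-fold higher number from compound 2 to compound 3 (0.16 log units; within the scatter) stays inside the scatter, and the step of a 1.3-fold lower number from compound 1 to compound 3 (0.12 log units; within the scatter) does the same, so the three groups tried at this place, (2-methoxyphenyl)sulfanyl, 4-fluorophenoxy and 4-methylphenoxy, cannot be ranked. The second of these steps is the only one that keeps the phenoxy link and alters just the group on the aromatic ring, and methyl in place of fluoro gives no difference that can be read. Nothing measured here offers a reason for any of these numbers.

The step from the sulfanyl compound to the phenoxy compound alters the linking atom and the ring substituent together, so a 2-methoxyphenoxy group would be needed to separate the two. Also open, going by these compounds, is how a carboxylic acid or an amine in place of the methyl group, or a longer chain at this place, would read in this assay and whether any such group would move the number beyond the scatter.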